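Dropping the Methoxy from Compound 3

The source may hold more compounds than are shown below. What is called first, only, known or untested is meant among the compounds shown, and "the series" means these compounds.

Compound 1, `COc1ccccc1NC1=CC(=O)c2c(nc3n2[C@H]2OC[C@@H](O)[C@H]2OC3)C1=O`, gives 6580 nM in a functional assay on MCF7 cells (Homo sapiens) for inhibition, read by sulforhodamine B assay; on this read-out higher numbers stand for weaker inhibition and lower numbers for stronger inhibition.
Compound 2, `O=C1C(Nc2ccc(C(F)(F)F)cc2)=CC(=O)c2c1nc1n2[C@H]2OC[C@@H](O)[C@H]2OC1`, reaches only a limit of this assay, > 4000 nM.
Compound 3, `COc1ccccc1NC1=CC(=O)c2nc3n(c2C1=O)[C@H]1OC[C@@H](O)[C@H]1OC3`, likewise reaches only a limit, > 4000 nM.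

Compound 3 thus stands at the limit of > 4000 nM in this assay, at which 2 of the 3 values shown sit; compound 1 alone shows a number. Compound 4, `O=C1C=C(Nc2ccccc2)C(=O)c2c1nc1n2[C@H]2OC[C@@H](O)[C@H]2OC1`, differs from compound 3 by hydrogen in place of methoxy on an aromatic carbon. Among the compounds with values here, the only single-place step measured, a step that the limit leaves unreadable from compound 1 to compound 2, is itself unreadable and alters a different group, so no measured step bears on this change. Accordingly no direction is expected for a step that the limit leaves unreadable from compound 3 to compound 4 in this assay beyond the scatter, and a limit is about as likely as a number. Compound 4 is estimated at 8000 nM in this assay, within 2500 nM to 30000 nM.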

Compound 4, half-maximal inhibitory concentration: > 4000 nM
Compound 4 ended at the assay's limit; the forecaster's own chance of this, stated with the estimate: 60%; the middle value is on the limit's open side.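

Compound 3 and compound 4 both end at a limit of this assay, so no step can be read between them: the limit of > 4000 nM in this assay, at which 3 of the 4 values shown sit.

The compounds shown leave open whether hydrogen in place of methoxy changes inhibition at all, in either direction.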